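A few compounds are considered here, and "the series" means these few. Any claim that something is new, unique, unknown or untested is made for them only; others in the source may bear on it.

Working notes on the series.

Compound 3 `COc1cc(COc2cc(N)c(Cl)cc2C(=O)CCCCN2CCC(OC)CC2)cc(OC)c1` gives 8.4 in a functional assay for antagonist activity at 5-hydroxytryptamine receptor 4 (Rattus norvegicus); on this read-out higher numbers stand for higher potency (the scale is a negative logarithm) and lower numbers for lower potency; its value lies within the scatter of both neighbours, as compound 1 `COc1cc(COc2cc(N)c(Cl)cc2C(=O)CCCCN2CCCCC2)cc(OC)c1` gives 8.5 and compound 2 `COc1cc(COc2cc(N)c(Cl)cc2C(=O)CCCCN2CCC(O)CC2)cc(OC)c1` gives 8.3, and the steps of a number 0.10 log units lower from compound 1 to compound 3 (within the scatter) and a number 0.10 log units higher from compound 2 to compound 3 (within the scatter) are both within the scatter. The third measured step, a number 0.20 log units lower from compound 1 to compound 2 (within the scatter), is also within the scatter.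

Compound 4 `COc1cc(COc2cc(N)c(Cl)cc2C(=O)CCCCN2CCC(NS(C)(=O)=O)CC2)cc(OC)c1` is the next member, not yet measured. Its change from compound 3 is methanesulfonamido in place of methoxy on a saturated ring carbon. The measured steps that touch this position, hydroxy for hydrogen, methoxy for hydrogen and methyl for hydrogen on the oxygen, all stayed within the scatter, so the substituent on this saturated ring carbon has so far not moved this assay. Within the data shown here, no measured step covers a sulfonamide group here, so the expectation rests on the pattern that the position tolerates substitution.

Compound 4 is therefore expected to give about 8.2, with a range of 7.6 to 8.7, a step of a number 0.20 log units lower from compound 3 to compound 4 (within the scatter), which is expected to stay within the scatter.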

Compound 4, negative logarithm of the antagonist equilibrium constant: 8.4
For compound 4 the middle estimate is 0.20 log units below the measured one, within the range that was stated.
By their numbers in this assay, from the lowest: compounds 2, 3, 4 and 1 (each within the scatter of the next).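

In this assay (this assay), the saturated ring carbon three ring bonds from the ring nitrogen also accepts methanesulfonamido, which brings more heavy atoms than methoxy and adds a hydrogen-bond donor, and all three new steps stay within the scatter (no change at the digits printed from compound 3 to compound 4 (within the scatter); a number 0.10 log units higher from compound 2 to compound 4 (within the scatter); a number 0.10 log units lower from compound 1 to compound 4 (within the scatter)). Earlier steps covered only hydroxy and methoxy, so the flat pattern now spans compound 1, compound 2, compound 3 and compound 4, with none of them going against it. No supporting data on this result are available to account for that flatness.

As far as these compounds go, whether an amine, a carboxylic acid or a longer chain on this carbon would also stay within the scatter remains open. From the compounds shown here alone, the shared core is constant throughout, so it also remains open whether this tolerance would hold on a different core.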